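Compound 3: a hept-1-en-1-yl chain on the shared core

The source may hold more compounds than are shown below. What is called first, only, known or untested is meant among the compounds shown, and "the series" means these compounds.

In an ADME assay on J774 cells (Mus musculus) for cytotoxicity (a lower number here means that less compound is needed, a higher number that more compound is needed for the effect), compound 1 `COc1cc2[nH]c(C)c(C)c(=O)c2cc1Cl` gives 12200 nM and compound 2 `C=C(CCCCC)c1c(C)[nH]c2cc(OC)c(Cl)cc2c1=O` gives 18900 nM, so the two stand within the scatter of each other. Compound 3 `CCCCC/C=C/c1c(C)[nH]c2cc(OC)c(Cl)cc2c1=O` has the same atoms as compound 2, joined differently: a group of 7 heavy atoms (7 carbon; no ring) in place of a group of 7 heavy atoms (7 carbon; no ring), on an aromatic carbon. Among the measured compounds shown here, the only measured step that bears on this change, a 1.5-fold higher number from compound 1 to compound 2 (0.19 log units; within the scatter), put a group of 7 heavy atoms in place of one carbon atom on an aromatic carbon and stayed within the scatter. No step beyond the scatter is therefore expected in this assay, and the estimated step is a 1.1-fold lower number from compound 2 to compound 3 (0.02 log units; within the scatter). For compound 3 the expected value is 18000 nM, with an estimated range of 9000 nM to 36000 nM.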

Compound 3, half-maximal effective concentration in the J774 assay: > 31200 nM
Compound 3: no number, only a limit (the forecaster's own chance of this, stated with the estimate: 5%); at least 1.7-fold (0.23 log units) between middle value and limit.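

In the J774 assay compound 3 gives > 31200 nM, no number, only a limit: the limit of > 31200 nM in the J774 assay, at which 1 of the 3 values shown sits.

Hept-1-en-1-yl in place of methyl on this aromatic carbon gives an at least 2.5-fold higher number from compound 1 to compound 3 (0.40 log units; beyond the scatter), the first step in the series beyond the scatter. In the J774 assay moving the chain's attachment gives an at least 1.6-fold higher number from compound 2 to compound 3 (0.21 log units; that floor lies within the scatter), so this floor does not separate the two chains. In a physicochemical assay for lipophilicity, at pH 7.4 (a lower number here means a more polar compound, a higher number a more lipophilic compound), compound 2 gives 3.58 and compound 3 gives 3.57. In the physicochemical assay the same change gives a number 0.01 log units lower from compound 2 to compound 3 (within the scatter).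

Going by these compounds, the true value of compound 3 remains unknown. Also open, on these data alone, is how a saturated heptyl chain, a shorter chain or an amine on this carbon would read in the J774 assay.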